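The compounds below may be only part of what the source reports. "The series", "measured", "known", "first", "only" and "open" are said of these compounds alone.

Working notes on the series. In an assay for inhibition of histone acetyltransferase KAT2B (Homo sapiens), read by fluorescence (on this read-out higher numbers stand for weaker inhibition and lower numbers for stronger inhibition), compound 1 `O=c1c2cc([N+](=O)[O-])cnc2sn1-c1ccc([N+](=O)[O-])cc1` gives 11800 nM, compound 2 `O=c1c2cccnc2sn1-c1ccc([N+](=O)[O-])cc1` gives 4100 nM, and compound 3 `Cc1cnc2sn(-c3ccc(Oc4ccccc4)cc3)c(=O)c2c1` gives 12900 nM. Compound 3 stands highest of the three numbers; its gap to compound 1 lies within the scatter, its gap to compound 2 beyond it. Compound 4 `Cc1cnc2sn(-c3ccc([N+](=O)[O-])cc3)c(=O)c2c1` differs from compound 3 by nitro in place of phenoxy on an aromatic carbon. For the measured compounds named here, no measured step touches the phenoxy group; the only step on record, a 2.9-fold lower number from compound 1 to compound 2 (0.46 log units; beyond the scatter), puts hydrogen in place of nitro on an aromatic carbon and bears on the present change only loosely. Compound 2, which also carries a nitro group, sits at the low end with 4100 nM. A modest move toward lower numbers is therefore expected, a 1.8-fold lower number from compound 3 to compound 4 (0.27 log units; within the scatter). Compound 4 is estimated at 7000 nM, within 2500 nM to 20000 nM.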

Compound 4, half-maximal inhibitory concentration: 15300 nM
The estimate for compound 4 lay 2.2-fold (0.34 log units) below the measured number, and the stated range covers the measured number.
By their numbers in this assay, from the lowest: compound 2; then compounds 1, 3 and 4 (each within the scatter of the next).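

Nitro in place of phenoxy on this aromatic carbon, a 1.2-fold higher number from compound 3 to compound 4 (0.07 log units; within the scatter), shows that the smaller group without a ring and the larger ring-bearing group cannot be told apart here. On the core, methyl in place of hydrogen gives a 3.7-fold higher number from compound 2 to compound 4 (0.57 log units; beyond the scatter), whereas methyl in place of nitro gives a 1.3-fold higher number from compound 1 to compound 4 (0.11 log units; within the scatter), so methyl and nitro cannot be told apart there, and only hydrogen gives a lower number. No supporting data explain these steps. Going by these compounds, it remains open whether an amine or a carboxylic acid on the aromatic carbon would shift the number, and whether hydrogen on the core would give a lower number with phenoxy in place of nitro.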